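The source may report more compounds than this note shows. Statements on the series, on what has been measured and on what is new or still open speak of the compounds shown alone.

Compound 3 `CCn1ncc2c(F)cc(-c3ccc(C(CC)(CC)c4nnc(C)[nH]4)c(=O)[nH]3)cc21` gives 90 nM in a functional assay on CHO cells for antagonist activity at prostaglandin E2 receptor EP3 subtype (Homo sapiens), read by cAMP accumulation; a higher number here means a weaker inhibitor, a lower number a stronger inhibitor. Among the three compounds measured, this is the highest number: compound 1 `CC(C)C(c1nnc[nH]1)c1ccc(-c2ccc3cccc(F)c3c2)[nH]c1=O` gives 21 nM in this assay, and compound 2 `CC(C)C(Nc1nccs1)c1ccc(-c2ccc3cccc(F)c3c2)[nH]c1=O` gives 10 nM in this assay, both clearly below compound 3.

Compound 4 `CCn1ncc2c(F)cc(-c3ccc(C(CC)(CC)c4nncn4C)c(=O)[nH]3)cc21` has not yet been measured. It differs from compound 3 in one place: 4-methyl-4H-1,2,4-triazol-3-yl in place of 5-methyl-4H-1,2,4-triazol-3-yl on a saturated chain carbon bound to an aromatic carbon and two saturated chain carbons The two groups hold the same atoms and the same ring, and only the placement of the methyl on that ring is changed.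

Among the compounds with values here, no measured step makes this same change. Within the data shown here, the only step available exchanges the whole ring for a different group, a 2.1-fold lower number from compound 1 to compound 2 (0.32 log units; beyond the scatter), a modest shift. Moving a methyl within the same ring looks like a smaller change than that, so no step beyond the scatter is expected for compound 4, and the expected step is a 1.2-fold higher number from compound 3 to compound 4 (0.09 log units; within the scatter). Compound 4 is therefore estimated to give about 110 nM in this assay, within a range from 40 nM to 300 nM.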

Compound 4, half-maximal inhibitory concentration: 120 nM
Compound 4: the middle estimate sits 1.1-fold (0.04 log units) below what was measured; measured number inside the range.
By their numbers in this assay, from the lowest: compound 2; then compound 1; then compounds 3 and 4 (each within the scatter of the next).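

In this assay, placing the methyl differently on the triazole, on a saturated chain carbon bound to an aromatic carbon and two saturated chain carbons, gives a 1.3-fold higher number from compound 3 to compound 4 (0.12 log units; within the scatter), so the two compounds cannot be told apart. The group that leaves has 1 hydrogen-bond donor and the group that enters has 0 hydrogen-bond donors, so on this core the donor on the ring is not needed to keep the number in this range. Nothing available explains this result.

Going by these compounds, it remains open whether the same swap would give so small a step on the core of compound 1. On these data alone, it also remains open whether a carboxylic acid or an amine on this same carbon would keep the number in this range, or whether a triazole ring is needed there at all.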